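Propargyl-to-methyl step on the desfluoro member of the series

This account rests on a few compounds, and the source may have more. Where it says the series, first, only, none or still open, it means among the compounds named here.

Measured compounds in an assay on L1210 cells for inhibition of Thymidylate synthase (Mus musculus); a higher number here means a weaker inhibitor, a lower number a stronger inhibitor:
compound 1 `C#CCN(Cc1cc2c(O)nc(C)nc2cc1C)c1ccc(C(=O)N[C@@H](CCC(=O)O)C(=O)N(C)[C@@H](CCC(=O)O)C(=O)O)c(F)c1`, 1.1 nM
compound 2 `Cc1nc(O)c2cc(CN(C)c3ccc(C(=O)N[C@@H](CCC(=O)O)C(=O)N(C)[C@@H](CCC(=O)O)C(=O)O)c(F)c3)c(C)cc2n1`, 3 nM
compound 3 `C#CCN(Cc1cc2c(O)nc(C)nc2cc1C)c1ccc(C(=O)N[C@@H](CCC(=O)O)C(=O)N(C)[C@@H](CCC(=O)O)C(=O)O)cc1`, 2.6 nM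

Compound 3 stands second highest of the three numbers in this assay; compound 2 lies within the scatter of it, while compound 1 sits clearly lower, a difference of a 2.4-fold higher number from compound 1 to compound 3 (0.37 log units; beyond the scatter).

Compound 4 `Cc1nc(O)c2cc(CN(C)c3ccc(C(=O)N[C@@H](CCC(=O)O)C(=O)N(C)[C@@H](CCC(=O)O)C(=O)O)cc3)c(C)cc2n1` is the next member and is not yet measured. The change from compound 3 to compound 4 is hydrogen in place of ethynyl on a saturated chain carbon bound to a nitrogen on an aromatic ring; read one bond further out it is propargyl to methyl.

Among the compounds with values here, one measured step bears on it directly: the same replacement on the fluoro-bearing pair gave a 2.7-fold higher number from compound 1 to compound 2 (0.44 log units; beyond the scatter). Within the data shown here, the other step, a 2.4-fold higher number from compound 1 to compound 3 (0.37 log units; beyond the scatter), shows that removing fluoro costs a comparable modest amount, so the two changes appear roughly additive across the three measured compounds, though no compound carrying both changes has yet been tested. On this basis the number for compound 4 is expected to rise, by about a 2.7-fold higher number from compound 3 to compound 4 (0.43 log units; beyond the scatter). Compound 4 is therefore estimated at 7 nM, with a range of 3.5 nM to 14 nM.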

Compound 4, inhibition constant: 8.2 nM
Compound 4: the middle estimate sits 1.2-fold (0.07 log units) below what was measured; the measured number falls inside the stated range.
By their numbers in this assay, from the lowest: compound 1; then compounds 3 and 2 (each within the scatter of the next); then compound 4.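

In this assay, the propargyl to methyl change now reads on the core without fluoro too, a 3.2-fold higher number from compound 3 to compound 4 (0.50 log units; beyond the scatter), and its size carries over from the fluoro-bearing pair: the same change on two cores in this assay, a 2.7-fold higher number (0.44 log units; beyond the scatter) from compound 1 to compound 2 and a 3.2-fold higher number (0.50 log units; beyond the scatter) from compound 3 to compound 4, 1.2-fold (0.06 log units) apart, within the scatter of two such steps. The change from fluoro to hydrogen on an aromatic carbon also holds its size with methyl in place of propargyl, a 2.7-fold higher number from compound 2 to compound 4 (0.44 log units; beyond the scatter): the same change on two cores in this assay, a 2.4-fold higher number (0.37 log units; beyond the scatter) from compound 1 to compound 3 and a 2.7-fold higher number (0.44 log units; beyond the scatter) from compound 2 to compound 4, 1.2-fold (0.06 log units) apart, within the scatter of two such steps. The two changes therefore read as additive across all four compounds, none of which goes against this, and neither change alters the size of the other within the scatter.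

The compounds shown leave open how an ethyl group or a longer chain ending in a hydroxyl would compare with methyl and propargyl at this site. They also leave open whether chloro or methoxy on that aromatic carbon would follow fluoro.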